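The source may report more compounds than this note shows. Statements on the series, on what has been measured and on what is new or still open speak of the compounds shown alone.

Measured in an ADME assay on microsomes from liver (Mus musculus) for metabolic stability, read by LC-MS, with a stated time of 60 min, tested at 500 uM; on this read-out higher numbers stand for a more stable compound and lower numbers for a less stable compound:
Compound 1 `COc1cc2c(cc1OC)CN(c1ccc(C=O)cc1)CC2`: 0.4%
Compound 2 `COc1cc2c(cc1OC)CN(c1ccccn1)CC2`: 0.2%

Compound 2 gives 0.2%, and compound 1 gives 0.4%. These two numbers lie within the usual scatter of each other, so neither can be ranked above the other, and very little of either compound is left at the end of the test.

Compound 3 `COc1cc2c(cc1OC)CN(c1ccc(F)cc1)CC2` keeps the shared core but carries 4-fluorophenyl in place of pyridin-2-yl on an amine nitrogen in a ring. Among the measured compounds shown here, no measured pair shows what a single swap of this kind does in this assay, so any forecast is uncertain. With compound 2 at 0.2% as the starting point, only a small upward move or none is expected. The expected change a number 0.8 percentage points higher from compound 2 to compound 3 (within the scatter) stays within the scatter. For compound 3, the estimated value is 1%, with an expected range from 0.1% to 8%.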

Compound 3, percent of the compound remaining: 0.6%
Compound 3: the middle estimate sits 0.4 percentage points above what was measured, within the range that was stated.
By their numbers in this assay, from the lowest: compounds 2, 1 and 3 (each within the scatter of the next).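

Putting 4-fluorophenyl in place of pyridin-2-yl on an amine nitrogen in a ring gives a number 0.4 percentage points higher from compound 2 to compound 3 (within the scatter) in this assay, so this swap cannot be told apart from no change. Fluoro in place of formyl on an aromatic carbon gives a number 0.2 percentage points higher from compound 1 to compound 3 (within the scatter) and reads the same way, so all three aromatic groups on this nitrogen leave the compounds together, with very little remaining at the end of the test. Nothing available here explains these low numbers.

From the compounds shown here alone, whether any other group at this position could lift the number beyond the scatter remains open, for example a carboxylic acid on the aromatic ring or an acetyl group on the nitrogen. Also open, going by these compounds, is what replacing the methoxy groups on the shared core would do.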